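Does a freed hydroxy wake an inactive compound?

The source may hold more compounds than are shown below. What is called first, only, known or untested is meant among the compounds shown, and "the series" means these compounds.

Measured so far in a functional assay on HL-60 cells (Homo sapiens) for inhibition, read by MTT assay, with a stated time of 72 h; a lower number here means a stronger inhibitor, a higher number a weaker inhibitor
compound 1 `O=C(c1oc(C(F)(F)F)nc1-c1ccccc1F)N1CCN(c2cccc(Cl)c2)CC1` gives "not active" (no number reported)
compound 2 `COc1ccc(-c2nc(C)oc2C(=O)N2CCN(c3cccc(Cl)c3)CC2)cc1OC` gives "not active" (no number reported)
compound 3 `CCc1nc(-c2cccc(F)c2)c(C(=O)N2CCN(c3cccc(Cl)c3)CC2)o1` gives 317 nM

Compound 2 stands without a single number. It can only be placed with compound 1 as a compound that showed no activity, and compound 3 alone carries a figure. Compound 4 `COc1ccc(-c2nc(C)oc2C(=O)N2CCN(c3cccc(Cl)c3)CC2)cc1O` still awaits testing. The change hydrogen in place of methyl on an oxygen on an aromatic ring puts hydrogen in place of methyl on an oxygen on an aromatic ring, methoxy to hydroxy. Among the measured compounds shown here, no measured pair shows what this swap does. A modest step toward a stronger inhibitor in this assay is expected, though a result of no activity remains quite possible. The estimate for compound 4 is 3000 nM with 400 nM to 20000 nM as the expected range.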

Compound 4, half-maximal inhibitory concentration: "not active" (no number reported)
Compound 4 has no reported number here; there is nothing to compare the estimate with.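

In this assay, among the compounds shown here, compound 2 and compound 4 both carry no number, leaving no step to read between them, and no further evidence bears on this result. The compounds shown leave open whether methoxy to hydroxy changes activity in any compound with a measurable value.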